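The compounds below may be only part of what the source reports. "The series", "measured", "known", "first", "only" and "open" are said of these compounds alone.

Compound 3 `Cc1cccc(/C(N)=N/NC(=S)N2CCCC2)n1` gives 8.7% in a functional assay on HeLa cells (Homo sapiens) for cytotoxicity, read by MTT assay, with a stated time of 72 h, tested at 1 uM (a lower number here means less inhibition of growth, a higher number more inhibition of growth at the concentration tested), the lowest of the three numbers measured here. Compound 2 `N/C(=N\NC(=S)N1CCOCC1)c1ccccn1` gives 12.7%, a value within the scatter of compound 3, so the two cannot be ordered. Going by the values given here, compound 1 `Cc1cccc(/C(N)=N/NC(=S)N2CCCCC2)n1` gives 27%, and the step of a number 18.3 percentage points lower from compound 1 to compound 3 (beyond the scatter) is the only measured step, a modest drop when the ring on the thiocarbonyl carbon shrinks by one member.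

Compound 4 `Cc1cccc(/C(N)=N/NC(=S)N2CCOCC2)n1` differs from compound 3 in one place: morpholin-4-yl in place of pyrrolidin-1-yl on a thiocarbonyl carbon. Among the compounds with values here, no measured step bears directly on this exchange. Compound 2 carries the same morpholin-4-yl group, but on a core without the methyl group, and its value and that of compound 3 lie within the scatter of each other, which gives no sign of a large shift. Within the data shown here, the one measured step, from a six-membered to a five-membered ring, was modest. Compound 4 is therefore expected to show a step of a number 4.3 percentage points higher from compound 3 to compound 4 (within the scatter), within the scatter. For compound 4 the estimate in this assay is 13%, with a range from 4% to 25%.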

Compound 4, percent growth inhibition at one concentration: 25.7%
For compound 4 the middle estimate is 12.7 percentage points below the measured one; measured number outside the range, above it.
By their numbers in this assay, from the lowest: compounds 3 and 2 (each within the scatter of the next); then compounds 4 and 1 (each within the scatter of the next).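

In this assay, morpholin-4-yl in place of pyrrolidin-1-yl on the thiocarbonyl carbon gives a number 17 percentage points higher from compound 3 to compound 4 (beyond the scatter), whereas morpholin-4-yl in place of piperidin-1-yl gives a number 1.3 percentage points lower from compound 1 to compound 4 (within the scatter), so these two six-membered rings cannot be told apart here, and compound 3, with its five-membered ring, lies below both. The methyl group on the aromatic carbon now has a measured step of its own, a number 13 percentage points higher from compound 2 to compound 4 (beyond the scatter), though only with morpholin-4-yl as the ring on the thiocarbonyl carbon. No measured evidence accounts for either difference.

Going by these compounds, whether the methyl step carries over to compounds with piperidin-1-yl or pyrrolidin-1-yl remains open. Also open, on these data alone, is how piperazin-1-yl or an open-chain dimethylamino group on the thiocarbonyl carbon, or an ethyl group in place of the methyl, would compare.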